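Swapping trifluoromethyl for fluoro at a flat cytotoxicity level

This account rests on a few compounds, and the source may have more. Where it says the series, first, only, none or still open, it means among the compounds named here.

In an ADME assay on CHO cells (Cricetulus griseus) for cytotoxicity, read by MTT assay (on this read-out higher numbers stand for lower toxicity in this test and lower numbers for higher toxicity in this test), compound 1 (`C[C@@H]1CN(C(=O)c2ccnc(Nc3nc4cnc(Nc5ccc(F)c(C(F)(F)F)c5)cc4[nH]3)c2)C[C@H](C)N1`) gives 29000 nM as its reading. Compound 2 (`C[C@@H]1CN(C(=O)c2ccnc(Nc3nc4cnc(Nc5ccc(F)c(C(F)(F)F)c5)cc4[nH]3)c2)C[C@H](C)O1`) gives 30000 nM and so stands level with compound 1, within the scatter. Compound 3 (`C[C@@H]1CN(C(=O)c2ccnc(Nc3nc4cnc(Nc5ccc(F)c(F)c5)cc4[nH]3)c2)C[C@H](C)O1`) carries fluoro in place of trifluoromethyl on an aromatic carbon, ortho to a fluoro group, turning 4-fluoro-3-(trifluoromethyl)phenyl into 3,4-difluorophenyl (fluoro in place of trifluoromethyl on an aromatic carbon) relative to compound 2. Among the measured compounds shown here, the only measured step is a 1.0-fold higher number from compound 1 to compound 2 (0.01 log units; within the scatter) and it concerns a different group, so it gives no direct guide to this change. Compound 2 at 30000 nM therefore remains the natural anchor. The expected outcome is no shift beyond the scatter, with a 1.1-fold higher number from compound 2 to compound 3 (0.04 log units; within the scatter) as the estimated step. For compound 3 the estimated value is 33000 nM with an expected range from 14000 nM to 75000 nM in this test.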

Compound 3, half-maximal cytotoxic concentration: > 50000 nM
Compound 3 gave a limit, no number; the forecaster's own chance of this, stated with the estimate: 20%; middle value at least 1.5-fold (0.18 log units) from the limit.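

Among the compounds shown here, compound 3 is the first view of the aromatic ring, as compound 1 and compound 2 differ only in the group on the carbonyl carbon. Going from 4-fluoro-3-(trifluoromethyl)phenyl to 3,4-difluorophenyl gives an at least 1.6-fold higher number from compound 2 to compound 3 (0.22 log units; that floor lies within the scatter), so this change brings no sign of higher toxicity in this test, though only a floor is known and that floor does not separate the two compounds. In this assay compound 3 gives > 50000 nM, which is a limit and not a number, so the true size of the step cannot be read: the limit of > 50000 nM in this assay, at which 1 of the 3 values shown sits.

On these data alone, whether chloro, a nitrile or an amine on this aromatic carbon would read the same stays open. Also open, as far as these compounds go, is whether the same swap would behave alike with the 3,5-dimethylpiperazin-1-yl group of compound 1.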